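The compounds below may be only part of what the source reports. "The series", "measured", "known", "first", "only" and "open" are said of these compounds alone.

Of the compounds shown here, three on a shared core have so far been measured in an assay on isolated protein for inhibition of ubiquitin carboxyl-terminal hydrolase 7 (Homo sapiens), with stated times of 30 min and 2 h; a lower number here means a stronger inhibitor, a higher number a weaker inhibitor. Compound 1 `Cn1nc2c(=O)n(CC3(O)CCN(Cc4ccc(-c5ccco5)cc4Cl)CC3)cnc2c1-c1ccc(CNCCO)cc1` gives 8.2 nM, compound 2 `Cn1nc2c(=O)n(CC3(O)CCN(Cc4ccc(-c5ccco5)cc4Cl)CC3)cnc2c1-c1ccc(C(N)=O)cc1` gives 80.8 nM, and compound 3 `Cn1nc2c(=O)n(CC3(O)CCN(Cc4ccc(-c5ccco5)cc4Cl)CC3)cnc2c1-c1ccc(OC(F)F)cc1` gives 179 nM. Compound 3 therefore stands highest of the three numbers: its nearest neighbour is compound 2, reached by a 2.2-fold higher number from compound 2 to compound 3 (0.35 log units; beyond the scatter), and its furthest is compound 1, reached by a 22-fold higher number from compound 1 to compound 3 (1.34 log units; beyond the scatter). Both of those steps arise from exchanging the group on one aromatic carbon of the pendant six-membered carbon ring, so that position is where the numbers have moved most.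

Compound 4 `Cn1nc2c(=O)n(CC3(O)CCN(Cc4ccc(-c5ccco5)cc4Cl)CC3)cnc2c1-c1ccc(C(=N)N)cc1` is not yet measured. It alters the same position: a group of 3 heavy atoms (1 carbon, 2 nitrogen; no ring) in place of a group of 4 heavy atoms (1 carbon, 1 oxygen, 2 fluorine; no ring), on an aromatic carbon. The measured steps that bear on it are a 2.2-fold higher number from compound 2 to compound 3 (0.35 log units; beyond the scatter) and a 22-fold higher number from compound 1 to compound 3 (1.34 log units; beyond the scatter); read in reverse, each shows that replacing difluoromethoxy with a nitrogen-bearing group gave a lower number. The entering group of compound 4 is closest in count to the carbamoyl of compound 2, so a downward step is expected, a 4.0-fold lower number from compound 3 to compound 4 (0.60 log units; beyond the scatter), since a 2.2-fold higher number from compound 2 to compound 3 (0.35 log units; beyond the scatter) was modest and a 22-fold higher number from compound 1 to compound 3 (1.34 log units; beyond the scatter) was large. Compound 4 is accordingly estimated at 45 nM, with a range from 12 nM to 160 nM.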

Compound 4, half-maximal inhibitory concentration: 87.5 nM
For compound 4 the middle estimate is 1.9-fold (0.29 log units) below the measured one; low and high end bracket the measured number.
By their numbers in this assay, from the lowest: compound 1; then compounds 2 and 4 (each within the scatter of the next); then compound 3.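

In this assay, the group of 3 heavy atoms (1 carbon, 2 nitrogen; no ring) cannot be told apart from the carbamoyl of compound 2, since a 1.1-fold higher number from compound 2 to compound 4 (0.03 log units; within the scatter) shows that exchanging the oxygen of that group for a nitrogen leaves the result within the usual scatter. The modest 2.0-fold lower number from compound 3 to compound 4 (0.31 log units; beyond the scatter) adds a second small group of this size that improves on difluoromethoxy, while an 11-fold higher number from compound 1 to compound 4 (1.03 log units; beyond the scatter) shows that neither small group reaches the ((2-hydroxyethyl)amino)methyl of compound 1, which remains the strongest of the four. No measurement is available that would account for these differences.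

What the compounds shown leave open is which part of the ((2-hydroxyethyl)amino)methyl group goes with the low number of compound 1, and whether a plain aminomethyl, a longer chain ending in a hydroxyl or a carboxylic acid on the same aromatic carbon would fall nearer to compound 1 or to compounds 2 and 4. They also leave open whether this order would hold with a change elsewhere on the shared core, as all four differ at this one position only.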